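A fluorophenyl swap and cell tolerance

A few compounds are considered here, and "the series" means these few. Any claim that something is new, unique, unknown or untested is made for them only; others in the source may bear on it.

Among the compounds with values here, in an ADME assay on Huh7.5.1 cells (Homo sapiens) for cytotoxicity, read by ATP content, with a stated time of 48 h (a lower number here means that less compound is tolerated, a higher number that more compound is tolerated), compound 1 (`Cc1ccc(C)c(-c2nc(CN3CCC(C(=O)NCCCN4C[C@H](C)C[C@H](C)C4)CC3)c(C)o2)c1`) gives 4070 nM and stands lowest of the two numbers so far. Compound 2 (`Cc1ccccc1-c1nc(CN2CCC(C(=O)NCCCN3CCC(C)CC3)CC2)c(C)o1`) gives 12300 nM as the higher number, beyond the usual scatter. Compound 3 (`Cc1oc(-c2ccc(F)cc2)nc1CN1CCC(C(=O)NCCCN2C[C@H](C)C[C@H](C)C2)CC1`) has 4-fluorophenyl in place of 2,5-dimethylphenyl on an aromatic carbon and has no number yet. Within the data shown here, no measured pair shows this swap alone. A modest rise is expected in this assay (a 1.8-fold higher number from compound 1 to compound 3 (0.27 log units; within the scatter)). Compound 2 at 12300 nM offers only a loose guide to that expectation. For compound 3 the estimate is 7500 nM with an expected range from 3000 nM to 18000 nM in this measurement.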

Compound 3, half-maximal cytotoxic concentration: 12800 nM
For compound 3 the middle estimate is 1.7-fold (0.23 log units) below the measured one; low and high end bracket the measured number.
By their numbers in this assay, from the lowest: compound 1; then compounds 2 and 3 (each within the scatter of the next).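

In this assay, within the data shown here, replacing 2,5-dimethylphenyl with 4-fluorophenyl gives a 3.1-fold higher number from compound 1 to compound 3 (0.50 log units; beyond the scatter), the first single-place step at this position. With the rest of compound 1 unchanged, the group on this aromatic carbon clearly affects how much compound the cells tolerate. No measurement here explains the step.

The swap removes both methyl groups and adds a fluorine at once, and the compounds shown do not separate these changes. As far as these compounds go, it also remains open how a plain phenyl, or an amine or a carboxylic acid on that ring, would behave.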